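Acrylamide-triazine series: amide-to-pyridyl swap on the aniline

The source may hold more compounds than are shown below. What is called first, only, known or untested is meant among the compounds shown, and "the series" means these compounds.

Measured so far:
compound 1 `C=CC(=O)Nc1cc(Nc2ncnc(Nc3ccc(C(=O)N4CCCCC4)cc3)n2)ccc1C`, 30600 nM
compound 2 `C=CC(=O)Nc1cccc(Nc2ncnc(Nc3ccc(C(=O)N4CCCCC4)cc3)n2)c1`, 5140 nM

Going by the values given here, in a functional assay on Raji cells (Homo sapiens) for antiproliferative activity, read by CCK-8 assay, with a stated time of 24 h (a lower number here means a stronger inhibitor, a higher number a weaker inhibitor), compound 2 gives 5140 nM, the lowest of the two numbers; the only neighbour is compound 1 at 30600 nM, and the step of a 6.0-fold lower number from compound 1 to compound 2 (0.77 log units; beyond the scatter) separates them. Compound 3 `C=CC(=O)Nc1cccc(Nc2ncnc(Nc3ccc(-c4cccnc4)cc3)n2)c1` differs from compound 2 by pyridin-3-yl in place of (piperidin-1-yl)carbonyl on an aromatic carbon. Among the compounds with values here, no measured step touches this position, so nothing speaks to its direction; the only expectation is that compound 3 stays in the same region, with a 1.7-fold lower number from compound 2 to compound 3 (0.23 log units; within the scatter) as a working guess. Compound 3 is therefore estimated at 3000 nM, within 600 nM to 15000 nM.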

Compound 3, half-maximal inhibitory concentration: 12400 nM
The estimate for compound 3 lay 4.1-fold (0.62 log units) below the measured number, and the stated range covers the measured number.
By their numbers in this assay, from the lowest: compound 2; then compound 3; then compound 1.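

In this assay, replacing (piperidin-1-yl)carbonyl with pyridin-3-yl gives a 2.4-fold higher number from compound 2 to compound 3 (0.38 log units; beyond the scatter). This shows that the position para to a large group affects the read-out, and that this aromatic ring does not reproduce the result of the non-aromatic amide it replaces. No evidence here accounts for the shift.

The compounds shown leave open whether the carbonyl or the attached ring carries the difference. A morpholine amide or an unsubstituted phenyl ring at this position would help separate the two.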